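From trifluoromethyl to trifluoromethoxy in a growth inhibition series

This account rests on a few compounds, and the source may have more. Where it says the series, first, only, none or still open, it means among the compounds named here.

Compound 1 `Cc1ccc2[nH]c(-c3ccc(-c4ccc(-c5cccc(Cl)c5)cc4)cc3)nc2c1`: 1210 nM
Compound 2 `Cc1ccc2[nH]c(-c3ccc(-c4ccc(-c5ccc(C(F)(F)F)cc5)cc4)cc3)nc2c1`: 31000 nM

Both values come from a functional assay on MCF7 cells (Homo sapiens) for inhibition, read by sulforhodamine B assay; on this read-out higher numbers stand for weaker inhibition of growth and lower numbers for stronger inhibition of growth. Compound 2 holds the higher of the two numbers, and the gap is wide: a 26-fold higher number from compound 1 to compound 2 (1.41 log units; beyond the scatter). That step puts 4-(trifluoromethyl)phenyl in place of 3-chlorophenyl on an aromatic carbon.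

Compound 3 `Cc1ccc2[nH]c(-c3ccc(-c4ccc(-c5ccc(OC(F)(F)F)cc5)cc4)cc3)nc2c1` has not yet been measured in this assay. It carries trifluoromethoxy in place of trifluoromethyl on an aromatic carbon, para to a large group: trifluoromethoxy in place of trifluoromethyl on an aromatic carbon.

Going by the values given here, only one measured step bears on this, and only indirectly. Among the compounds with values here, no measured compound carries trifluoromethoxy, so the data give no direct test of this swap. Still, a 26-fold higher number from compound 1 to compound 2 (1.41 log units; beyond the scatter) shows that a change to this substituted phenyl group can move the number a long way. Here the phenyl group and the place of its substituent stay the same, so a smaller step is expected. A slight lean toward a lower number rests only on compound 2 standing far above compound 1 at 1210 nM. The expected change is a 2.1-fold lower number from compound 2 to compound 3 (0.32 log units; beyond the scatter). For compound 3 the estimated value is 15000 nM, with an expected range of 4000 nM to 50000 nM.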

Compound 3, concentration for 50% growth inhibition: 31000 nM
Beside the measured number, compound 3's estimate is 2.1-fold (0.32 log units) below it, and the stated range covers the measured number.
By their numbers in this assay, from the lowest: compound 1; then compounds 2 and 3 (each within the scatter of the next).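

In this assay, trifluoromethoxy in place of trifluoromethyl on an aromatic carbon, para to a large group, gives no change at the digits printed from compound 2 to compound 3 (within the scatter) on this read-out, so the added oxygen and the hydrogen-bond acceptor it brings leave no trace in the number. The earlier compounds shown here could show only that moving from 3-chlorophenyl to 4-(trifluoromethyl)phenyl carried a large penalty; the new compound shows that this gap survives a change of the group itself, with a 26-fold higher number from compound 1 to compound 3 (1.41 log units; beyond the scatter) as the second large step of this kind. At this position, the two fluorinated groups therefore cannot be told apart, and both stand well away from the 3-chlorophenyl compound, although nothing available accounts for this result.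

As far as these compounds go, it remains open whether a chlorine, an amine or a carboxylic acid in this same place would bring the number down toward that of compound 1 or leave it with compound 2 and compound 3. Compound 1 also differs from both in the substituent and in its place on the phenyl ring, so the compounds shown cannot separate these two changes.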